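This account rests on a few compounds, and the source may have more. Where it says the series, first, only, none or still open, it means among the compounds named here.

Going by the values given here, in a physicochemical assay for pharmacokinetics (on this read-out higher numbers stand for a longer-lived compound and lower numbers for a shorter-lived compound), compound 1 (`C[C@@H](NC(=O)OC(C)(C)C)C(=O)Oc1cc(-c2oc3cc(O)cc(O)c3c(=O)c2O)ccc1O`) gives 0.0000297 h and holds the lowest of the three numbers measured so far. Compound 2 (`CC(C)(C)OC(=O)NCCCC(=O)Oc1cc(-c2oc3cc(O)cc(O)c3c(=O)c2O)ccc1O`) gives 0.000208 h in the same read-out. Compound 3 (`CC(C)(C)OC(=O)N[C@H]1CC[C@@H](C(=O)Oc2cc(-c3oc4cc(O)cc(O)c4c(=O)c3O)ccc2O)CC1`) gives 0.000331 h in this assay and, like compound 2, stands above compound 1 by more than the scatter.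

Compound 4 (`C[C@@H](N)C(=O)Oc1cc(-c2oc3cc(O)cc(O)c3c(=O)c2O)ccc1O`) has not yet been measured. It differs from compound 1 by hydrogen in place of tert-butoxycarbonyl on an amine nitrogen and so carries 1-aminoethyl where compound 1 carries 1-((tert-butoxycarbonyl)amino)ethyl. Among the compounds with values here, only one measured step touches this part of compound 1. That step, a 7.0-fold higher number from compound 1 to compound 2 (0.85 log units; beyond the scatter), lies beyond the scatter, but the tert-butoxycarbonyl stays in place there and only the chain changes. Within the data shown here, no measured pair shows the removal of that group, so the data give neither a size nor a direction for it. The expectation therefore stays close to compound 1, with a wide range on either side. The estimated step (a 1.3-fold higher number from compound 1 to compound 4 (0.13 log units; within the scatter)) is expected to remain within the scatter. For compound 4 the estimate is 0.00004 h (expected range from 0.000006 h to 0.0003 h).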

Compound 4, half-life: 0.000000889 h
Beside the measured number, compound 4's estimate is 45-fold (1.65 log units) above it; measured number below the stated range.
By their numbers in this assay, from the lowest: compound 4; then compound 1; then compounds 2 and 3 (each within the scatter of the next).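

Taking the tert-butoxycarbonyl off the amine nitrogen is the first change here that lowers the number in this assay, and it does so with a 33-fold lower number from compound 1 to compound 4 (1.52 log units; beyond the scatter), a large step in the opposite direction from the rise seen when the chain alone was altered with that group kept in place. Compound 4, with its free 1-aminoethyl group, also stands far from the longer protected chain, with a 230-fold lower number from compound 2 to compound 4 (2.37 log units; beyond the scatter), although that step changes the chain and removes the tert-butoxycarbonyl in one move, so it cannot be assigned to either change alone. The half-life of these compounds therefore depends strongly on whether this amine nitrogen carries the tert-butoxycarbonyl, yet nothing available accounts for the drop.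

Going by these compounds, it remains open whether removing the tert-butoxycarbonyl from compound 2 or compound 3 would give a step of like size, which a 3-aminopropyl chain would test for compound 2. Also open, on these data alone, is whether an acetyl or a methyl group on the same amine nitrogen would bring the number closer to that of compound 1 or to that of compound 4.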